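Changing the group on the ring nitrogen of compound 3

The source may hold more compounds than are shown below. What is called first, only, known or untested is meant among the compounds shown, and "the series" means these compounds.

Measured compounds:
compound 1, `CN(C)c1ccc(C2CC(c3ccc(-n4ccnc4)cc3)=NN2)cc1`, 7.6%
compound 2, `CN(C)c1ccc(C2CC(c3ccc(-n4cncn4)cc3)=NN2C(=O)c2cc(Cl)cc(Cl)c2)cc1`, 9.4%
compound 3, `CN(C)c1ccc(C2CC(c3ccc(-n4ccnc4)cc3)=NN2C(=O)c2cc(Cl)cc(Cl)c2)cc1`, 48.8%

In a functional assay on MDA-MB-231 cells (Homo sapiens) for inhibition, read by sulforhodamine B assay, tested at 10 uM (on this read-out higher numbers stand for more inhibition at the one concentration tested (going by the name of the read-out) and lower numbers for less inhibition), compound 3 gives the highest of the three numbers. Its nearest neighbour on the numbers is compound 2, whose value lies below that of compound 3 beyond the scatter, and compound 1 lies further below, also beyond the scatter. Compound 4, `CN(C)c1ccc(C2CC(c3ccc(-n4ccnc4)cc3)=NN2S(=O)(=O)c2ccc([N+](=O)[O-])cc2)cc1`, differs from compound 3 in one place: (4-nitrophenyl)sulfonyl in place of (3,5-dichlorophenyl)carbonyl on an amine nitrogen in a ring.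

Within the data shown here, two measured steps touch on this position. The step of a number 41.2 percentage points higher from compound 1 to compound 3 (beyond the scatter) shows that putting a group on this ring nitrogen made a large difference. The step of a number 39.4 percentage points higher from compound 2 to compound 3 (beyond the scatter) concerns another part of the molecule and does not bear directly on the change to compound 4. Among the measured compounds shown here, no measured pair compares two different groups on this ring nitrogen, so the direction of the exchange in compound 4 is open. Because the step of a number 41.2 percentage points higher from compound 1 to compound 3 (beyond the scatter) was large, a substantial move in either direction is possible; the estimate therefore stays near compound 3 with a wide range. Compound 4 is expected to give about 40%, between 10% and 70%, which is an expected step of a number 8.8 percentage points lower from compound 3 to compound 4 (within the scatter).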

Compound 4, a percentage reported as inhibition, at one concentration (the size of the read-out at that concentration, not a potency): 41.5%
Beside the measured number, compound 4's estimate is 1.5 percentage points below it; low and high end bracket the measured number.
By their numbers in this assay, from the lowest: compounds 1 and 2 (each within the scatter of the next); then compounds 4 and 3 (each within the scatter of the next).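

In this assay, among these compounds, this is the first comparison of two different groups on this ring nitrogen, and it gives a number 7.3 percentage points lower from compound 3 to compound 4 (within the scatter) so (4-nitrophenyl)sulfonyl and (3,5-dichlorophenyl)carbonyl cannot be told apart here. Replacing hydrogen on the same nitrogen with the sulfonyl group gives a number 33.9 percentage points higher from compound 1 to compound 4 (beyond the scatter) and so the large rise no longer rests on the dichlorophenyl carbonyl group alone, but is seen with two groups that differ in both linker and ring substituents. Nothing given here explains why these two groups read alike.

From the compounds shown here alone, whether a small acetyl or methanesulfonyl group, with no aromatic ring, would hold this level on the ring nitrogen remains open. So does whether 1H-1,2,4-triazol-1-yl in place of 1H-imidazol-1-yl would have the same effect alongside the (4-nitrophenyl)sulfonyl group.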